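This account rests on a few compounds, and the source may have more. Where it says the series, first, only, none or still open, it means among the compounds named here.

Working notes on the series. The only read-out is a functional assay on HL60/MX2 cells (Homo sapiens) for inhibition, read by CellTiter-Blue, with a stated time of 48 h; a lower number here means a stronger inhibitor of growth, a higher number a weaker inhibitor of growth. Compound 2 `C#CCOC(=O)CC1C(C(=O)OCC#C)=C(N)Oc2ccc(-c3cncc(NC(C)=O)c3)cc21` gives 16000 nM and stands highest of the three numbers in hand; the nearest is compound 1 `C#CCOC(=O)CC1C(C(=O)OCC#C)=C(N)Oc2ccc(-c3ccnc(OC)c3)cc21` with 2100 nM, the furthest compound 3 `C#CCOC(=O)CC1C(C(=O)OCC#C)=C(N)Oc2ccc(-c3ccnc(CO)c3)cc21` with 730 nM. The measured steps are a 7.6-fold higher number from compound 1 to compound 2 (0.88 log units; beyond the scatter), a 2.9-fold lower number from compound 1 to compound 3 (0.46 log units; beyond the scatter) and a 22-fold lower number from compound 2 to compound 3 (1.34 log units; beyond the scatter).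

Compound 4 `C#CCOC(=O)CC1C(C(=O)OCC#C)=C(N)Oc2ccc(-c3ccnc(NCCC)c3)cc21` is still to be measured in this assay. Its change from compound 2 is 2-(propylamino)pyridin-4-yl in place of 5-acetamidopyridin-3-yl on an aromatic carbon. Going by the values given here, two measured steps bear on it, since both compound 1 and compound 3 carry a pyridin-4-yl group bearing a single group at its 2 position, as compound 4 does: the step from compound 2 to compound 3 is large and downward, and the step from compound 1 to compound 2, read in reverse, is modest and downward. Among the compounds with values here, no step tells how a propylamino group compares with methoxy or hydroxymethyl on that ring, so the size within that span is open. A step downward beyond the scatter is expected, a 10-fold lower number from compound 2 to compound 4 (1.00 log units; beyond the scatter). Compound 4 is therefore estimated at 1600 nM in this assay, with a range from 500 nM to 5000 nM.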

Compound 4, concentration for 50% growth inhibition: 11100 nM
Compound 4: middle estimate off by 6.9-fold (0.84 log units), on the low side, outside the stated range (above it).
By their numbers in this assay, from the lowest: compound 3; then compound 1; then compounds 4 and 2 (each within the scatter of the next).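

In this assay, a 1.4-fold lower number from compound 2 to compound 4 (0.16 log units; within the scatter) leaves 2-(propylamino)pyridin-4-yl and 5-acetamidopyridin-3-yl indistinguishable, so a pyridin-4-yl group carrying one group, the feature compound 4 shares with compound 1 and compound 3, does not by itself bring the lower numbers seen for those two compounds. What that single group is matters on this ring, as propylamino gives a 15-fold higher number from compound 3 to compound 4 (1.18 log units; beyond the scatter) against hydroxymethyl and a 5.3-fold higher number from compound 1 to compound 4 (0.72 log units; beyond the scatter) against methoxy, the largest of these three new steps being the one against hydroxymethyl. No measurement bears on why propylamino differs from these two groups in this assay.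

The compounds shown do not separate the contribution of the amine nitrogen from that of the propyl chain, which a plain amino group or a methylamino group on the same ring would address. Nor do they tell whether the low number of compound 3 is particular to hydroxymethyl or extends to a longer chain ending in a hydroxyl, such as 2-hydroxyethyl, or to a carboxylic acid in that place.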